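The source may hold more compounds than are shown below. What is called first, only, known or untested is meant among the compounds shown, and "the series" means these compounds.

Working notes on the series: compound 1 `CCOC(=O)N1[C@@H]2C=C[C@@](OC)(C(=O)c3c2cc(OC)c(OC)c3OCC)N1C(=O)OCC`, compound 2 `COc1cc2c(c(OCc3ccc(F)cc3)c1OC)C(=O)[C@]1(OC)C=C[C@H]2N(C(=O)OCC(C)C)N1C(=O)OCC(C)C` and the unmeasured compound 3 `COc1cc2c(c(O)c1OC)C(=O)[C@]1(OC)C=C[C@H]2N(C(=O)OCC(C)C)N1C(=O)OCC(C)C` share one core. In an ADME assay on KB cells (Homo sapiens) for cytotoxicity (a higher number here means that more compound is needed for the effect, a lower number that less compound is needed), compound 1 gives > 300 ug/mL, which is a limit of the assay and not a number. In this assay, compound 2 gives > 300 ug/mL, which is also a limit. The measured set therefore has no number yet: the limit of > 300 ug/mL in this assay, at which 2 of the 2 values shown sit. Among the measured compounds shown here, compound 2 thus stands at this limit, and no measured step is available to size a change. Compound 3 carries hydrogen in place of 4-fluorobenzyl on an oxygen on an aromatic ring, (4-fluorobenzyl)oxy to hydroxy: hydrogen in place of 4-fluorobenzyl on an oxygen on an aromatic ring. Starting from the limit of compound 2, a modest shift in this assay towards less compound needed is expected, though another limit remains likely. The expected move is an at least 1.3-fold lower number from compound 2 to compound 3 (0.13 log units; that floor lies within the scatter). For compound 3, the estimated value is 220 ug/mL, with an expected range of 60 ug/mL to 600 ug/mL.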

Compound 3, concentration for half-maximal effect: > 300 ug/mL
Compound 3: only a limit was reported; the forecaster's own chance of this, stated with the estimate: 60%; at least 1.3-fold (0.13 log units) between middle value and limit.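

In this assay compound 2 and compound 3 both give only a limit of the assay, and no step can be read between them. What hydrogen in place of 4-fluorobenzyl does to the number stays open, as every value shown is a limit: the limit of > 300 ug/mL in this assay, at which 3 of the 3 values shown sit.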